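The compounds below may be only part of what the source reports. "The series", "measured", "known", "first", "only" and "open" are said of these compounds alone.

Working notes on the series. Compound 1 `COc1ccccc1/C=C/C(=O)/C=C/c1ccc(OCc2cn(CCCCOc3cc(=O)oc4ccccc34)nn2)c(OC)c1` carries a 2-methoxyphenyl on a double-bonded chain carbon bound to a double-bonded chain carbon. Within the data shown here, in a functional assay on COLO 205 cells (Homo sapiens) for inhibition, read by sulforhodamine B assay, with a stated time of 48 h, tested at 50 uM (on this read-out higher numbers stand for more inhibition of growth at the one concentration tested and lower numbers for less inhibition of growth), compound 1 gives 47%, the lowest of the two numbers measured so far. Among the measured compounds shown here, compound 2 `COc1cc(/C=C/C(=O)/C=C/c2cc(OC)c(OC)c(OC)c2)ccc1OCc1cn(CCCOc2cc(=O)oc3ccccc23)nn1` differs from compound 1 in several places at once, so no single step between them is counted; in this assay compound 2 gives 74%, which is higher by an amount beyond the usual scatter. Compound 3 `COc1cc(/C=C/C(=O)/C=C/c2cccc3ccccc23)ccc1OCc1cn(CCCCOc2cc(=O)oc3ccccc23)nn1` has not yet been measured; it differs from compound 1 in one place only: naphthalen-1-yl in place of 2-methoxyphenyl on a double-bonded chain carbon bound to a double-bonded chain carbon. For the measured compounds named here, no measured pair shows the effect of this exchange, so the expectation rests on compound 1 alone. The step from compound 1 to compound 3 in this assay is expected to be small, a number 5 percentage points higher from compound 1 to compound 3 (within the scatter), not clearly beyond the scatter in either direction. Compound 3 is therefore estimated at 52%, within a range of 28% to 76%.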

Compound 3, percent growth inhibition at one concentration: 50%
The estimate for compound 3 lay 2 percentage points above the measured number; the range from low to high includes it.
By their numbers in this assay, from the lowest: compounds 1 and 3 (each within the scatter of the next); then compound 2.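

In this assay, among these compounds, naphthalen-1-yl in place of 2-methoxyphenyl on a double-bonded chain carbon bound to a double-bonded chain carbon gives a number 3 percentage points higher from compound 1 to compound 3 (within the scatter), the first reading of a single exchange. At this position, then, two six-membered aromatic rings of carbon only and no hydrogen-bond acceptor read within the scatter of one such ring with one acceptor, which the several simultaneous differences between compound 1 and compound 2 could not show. No measurement at hand explains this result.

From the compounds shown here alone, whether an amine or a carboxylic acid at this position would read the same remains open. Also open is which difference from compound 1 lies behind the value of compound 2, 74%.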